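Swapping the Aryl Ether for Trifluoromethyl

The compounds below may be only part of what the source reports. "The series", "measured", "known", "first", "only" and "open" are said of these compounds alone.

Measured so far:
compound 1, `CCCCCc1cc(C)c(C(=O)N=C(N)N)cc1S(C)(=O)=O`, 27 nM
compound 2, `Cc1cc(Sc2ccncc2)c(S(C)(=O)=O)cc1C(=O)N=C(N)N`, 13 nM
compound 3, `Cc1cc(Oc2cccc(Cl)c2)c(S(C)(=O)=O)cc1C(=O)N=C(N)N`, 21 nM

Compound 3 stands second highest of the three numbers in a functional assay for inhibition of sodium/hydrogen exchanger (Oryctolagus cuniculus) (a lower number here means a stronger inhibitor, a higher number a weaker inhibitor), with compound 1 nearest at a 1.3-fold lower number from compound 1 to compound 3 (0.11 log units; within the scatter) and compound 2 furthest at a 1.6-fold higher number from compound 2 to compound 3 (0.21 log units; within the scatter), both within the scatter. Compound 4, `Cc1cc(C(F)(F)F)c(S(C)(=O)=O)cc1C(=O)N=C(N)N`, has not been measured. The change from compound 3 to compound 4 is trifluoromethyl in place of 3-chlorophenoxy on an aromatic carbon. Within the data shown here, no measured step involves trifluoromethyl. The steps at this position, a 1.3-fold lower number from compound 1 to compound 3 (0.11 log units; within the scatter) and a 2.1-fold lower number from compound 1 to compound 2 (0.32 log units; beyond the scatter), show only small movement across three quite different groups, so a step of no more than modest size in this assay is expected for a 1.4-fold higher number from compound 3 to compound 4 (0.15 log units; within the scatter). Compound 4 is therefore estimated at 30 nM, between 10 nM and 90 nM.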

Compound 4, half-maximal inhibitory concentration: 37 nM
Compound 4: middle estimate off by 1.2-fold (0.09 log units), on the low side; the measured number falls inside the stated range.
By their numbers in this assay, from the lowest: compounds 2, 3, 1 and 4 (each within the scatter of the next, the first and the last beyond it).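

Trifluoromethyl, with no ring and only 4 heavy atoms, shows that this position, ortho to the methylsulfonyl group, needs no aromatic ring or long chain to stay in this range: this assay gives a 1.8-fold higher number from compound 3 to compound 4 (0.25 log units; within the scatter) and a 1.4-fold higher number from compound 1 to compound 4 (0.14 log units; within the scatter), both within the scatter. Only the comparison with the (pyridin-4-yl)sulfanyl group goes beyond the scatter, and modestly, at a 2.8-fold higher number from compound 2 to compound 4 (0.45 log units; beyond the scatter). No measurement offered here explains this result. The compounds shown leave open how an amine, a carboxylic acid or a plain hydrogen at this position would compare.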